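Ring methylation of a pyridyl urea: compound 3 to compound 4

The source may report more compounds than this note shows. Statements on the series, on what has been measured and on what is new or still open speak of the compounds shown alone.

Measured compounds:
compound 1, `Cc1cc(C)nc(N(CCNC(C)C)C(=O)N(C)C)c1`: 33%
compound 2, `Cc1cc(C)nc(N(CCN(C)C)C(=O)N(C)C)c1`: 58%
compound 3, `CC(C)N(CCN(C(=O)N(C)C)c1ccccn1)C(C)C`: 17%

Three ureas were examined in a functional assay on the whole organism (stomach) for inhibition, with Canis familiaris (Canis lupus familiaris) as the target, at a dose of 20 mg/kg by the oral route; a higher number here means a stronger effect of the compound at the dose given, a lower number a weaker effect. Compound 1 `Cc1cc(C)nc(N(CCNC(C)C)C(=O)N(C)C)c1` gives 33%, compound 2 `Cc1cc(C)nc(N(CCN(C)C)C(=O)N(C)C)c1` gives 58%, and compound 3 `CC(C)N(CCN(C(=O)N(C)C)c1ccccn1)C(C)C` gives 17%. Compound 3 stands lowest of the three numbers; compound 1 lies nearest to it, and compound 2 furthest.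

Among the compounds with values here, the only step among the measured compounds is a number 25 percentage points higher from compound 1 to compound 2 (beyond the scatter). That change sits on the chain amine, not on the ring.

Compound 4 `Cc1cccc(N(CCN(C(C)C)C(C)C)C(=O)N(C)C)n1` differs from compound 3 by methyl in place of hydrogen on an aromatic carbon. Within the data shown here, no measured step bears on a hydrogen-to-methyl exchange on the ring, so nothing measured tells how large such a step should be. With only the chain-amine step as a reference, and that step not touching the ring, the expectation is a step of a number 5 percentage points higher from compound 3 to compound 4 (within the scatter) in this assay, which is within the scatter. Compound 4 is therefore estimated at 22%, with a range from 5% to 45% in this assay.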

Compound 4, a percentage reported as inhibition, in the whole organism at one dose (the size of the read-out at that dose, not a potency): 87%
The estimate for compound 4 lay 65 percentage points below the measured number, outside the stated range (above it).
By their numbers in this assay, from the lowest: compound 3; then compound 1; then compound 2; then compound 4.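

In this assay the carbon next to the ring nitrogen turns out to be a place where one added methyl counts for a great deal: the change from pyridin-2-yl to 6-methylpyridin-2-yl gives a number 70 percentage points higher from compound 3 to compound 4 (beyond the scatter) with the diisopropylamino chain and the urea left as they were. Within the data shown here, the only earlier step, a number 25 percentage points higher from compound 1 to compound 2 (beyond the scatter) on the chain amine, never touched the ring and so gave no sign that the ring carbons mattered; this step, large where that one was modest, shows that a change of a single carbon on the ring can move this read-out further than that change on the chain did. Nothing in hand accounts for the size of this gain, so it stands as an observation without an explanation.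

The compounds shown leave open whether the gain belongs to methyl itself or would survive with an ethyl, a methoxy group or a chlorine atom on the same carbon. They also leave open how much of the effect depends on this place on the ring, and whether it would hold at doses other than the single one tested.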